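Swapping an Ether Side Chain for a Branched Alkyl

A few compounds are considered here, and "the series" means these few. Any claim that something is new, unique, unknown or untested is made for them only; others in the source may bear on it.

Of the compounds shown here, two sharing one core have been tested in a functional assay on ileum for inhibition of histamine H1 receptor (Cavia porcellus); a higher number here means a weaker inhibitor, a lower number a stronger inhibitor. Compound 1 `CCCCOCCn1c(N2CCCN(C)CC2)nc2ccccc21` gives 10 nM. Compound 2 `C#CCOCCn1c(N2CCN(C)CC2)nc2ccccc21` gives 12 nM, and this is the higher of the two numbers, though the difference from compound 1 lies within the usual scatter of repeated measurements, so the two behave alike in this assay.

Compound 3 `CCCC(C)Cn1c(N2CCN(C)CC2)nc2ccccc21` has not yet been measured. It differs from compound 2 in one place: 1-methylbutyl in place of (propargyloxy)methyl on a saturated chain carbon bound to an aromatic nitrogen. The oxygen-containing side chain, with its triple bond, gives way to a plain branched carbon chain of the same size.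

For the measured compounds named here, no measured pair here shows what such a change does. Since compound 1 and compound 2 carry different ether chains yet give numbers within the scatter of each other, the side chain seems to matter little so far. Compound 3 is therefore expected to give 20 nM, within a range from 6 nM to 70 nM. The expected step of a 1.7-fold higher number from compound 2 to compound 3 (0.22 log units; within the scatter) is small, leaning toward a higher number, and may not exceed the scatter.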

Compound 3, half-maximal inhibitory concentration: 500 nM
The estimate for compound 3 lay 25-fold (1.40 log units) below the measured number, and the stated range ends below it.
By their numbers in this assay, from the lowest: compounds 1 and 2 (each within the scatter of the next); then compound 3.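

In this assay, putting 1-methylbutyl in place of (propargyloxy)methyl gives a 42-fold higher number from compound 2 to compound 3 (1.62 log units; beyond the scatter), so what stands on this saturated chain carbon bound to an aromatic nitrogen clearly matters. For the compounds shown here, compound 2 and compound 3 are the first pair here to differ in only one place, and their two groups have the same number of heavy atoms, so keeping that number alone does not preserve the inhibition. Nothing available explains the size of this step.

The oxygen, the triple bond and the branch all change in this one step, and the compounds shown cannot separate them. Still open, on these data alone, is how a straight pentyl chain, or a chain carrying a hydroxyl group or an amine where the ether oxygen stands, would behave at this position.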